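This account rests on a few compounds, and the source may have more. Where it says the series, first, only, none or still open, it means among the compounds named here.

Measured compounds:
compound 1, `N#Cc1cnc(NCc2cnccc2C(F)(F)F)cc1NC[C@H]1C[C@@H](O)C1`, 300 nM
compound 2, `N#Cc1cnc(NCc2cnccc2C(F)(F)F)cc1NC[C@H]1C[C@H](O)C1`, 700 nM
compound 3, `N#Cc1cnc(NCc2cnccc2C(F)(F)F)cc1N[C@H]1CC[C@H](O)CC1`, 350 nM

Of the compounds shown here, three sharing one core have been measured in an assay on isolated protein for inhibition of protein kinase C theta type (Homo sapiens), read by TR-FRET, with a stated time of 2 h; on this read-out higher numbers stand for weaker inhibition and lower numbers for stronger inhibition. Compound 1 gives the lowest of the three numbers; its nearest neighbour is compound 3, and the step of a 1.2-fold higher number from compound 1 to compound 3 (0.07 log units; within the scatter) stays within the scatter. Compound 2 lies furthest away, a 2.3-fold higher number from compound 1 to compound 2 (0.37 log units; beyond the scatter), and the only difference there is the fact that compounds 1 and 2 differ only in the configuration as drawn. Between compound 2 and compound 3 the step is a 2.0-fold lower number from compound 2 to compound 3 (0.30 log units; within the scatter).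

Compound 4, `CO[C@H]1CC[C@H](Nc2cc(NCc3cnccc3C(F)(F)F)ncc2C#N)CC1`, has not yet been measured. Its difference from compound 1 is 4-methoxycyclohexyl in place of (3-hydroxycyclobutyl)methyl on a nitrogen on an aromatic ring. Going by the values given here, of the measured steps, the one from compound 1 to compound 3 bears most directly on it, since compound 3 carries a 4-hydroxycyclohexyl at the same nitrogen and its step of a 1.2-fold higher number from compound 1 to compound 3 (0.07 log units; within the scatter) was within the scatter. Among the compounds with values here, no measured pair tests a 4-methoxycyclohexyl against a 4-hydroxycyclohexyl, so that part of the change stands without precedent here. On this basis the expected step in this assay is a 1.5-fold higher number from compound 1 to compound 4 (0.18 log units; within the scatter), a small move toward a higher number that may well lie within the scatter. Compound 4 is therefore estimated at 450 nM, with a range from 150 nM to 1400 nM.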

Compound 4, half-maximal inhibitory concentration: 1100 nM
Estimate against measurement, compound 4: 2.4-fold (0.39 log units) below; measured number inside the range.
By their numbers in this assay, from the lowest: compounds 1, 3, 2 and 4 (each within the scatter of the next, the first and the last beyond it).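

In this assay, going by these compounds alone, the step of a 3.1-fold higher number from compound 3 to compound 4 (0.50 log units; beyond the scatter) is the first reading of methyl in place of hydrogen on this oxygen, and it lies beyond the scatter, so at this position the methoxy and hydroxy forms of the cyclohexyl group are not interchangeable. The earlier compounds shown here showed only that a 4-hydroxycyclohexyl could stand in for the (3-hydroxycyclobutyl)methyl on this nitrogen with no change beyond the scatter, whereas the step of a 3.7-fold higher number from compound 1 to compound 4 (0.56 log units; beyond the scatter) shows that the 4-methoxycyclohexyl cannot. The step of a 1.6-fold higher number from compound 2 to compound 4 (0.20 log units; within the scatter) stays within the scatter, however, so compound 4 is set apart from compound 1 and compound 3 but not from compound 2.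

Nothing given here accounts for the step brought by the methyl on this oxygen. From the compounds shown here alone, it remains open whether an amine or an ethoxy group in place of the hydroxy on the cyclohexyl would read like compound 3 or like compound 4, and whether a methoxy on the cyclobutyl ring of compound 1 would bring a step of similar size.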